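A few compounds are considered here, and "the series" means these few. Any claim that something is new, unique, unknown or untested is made for them only; others in the source may bear on it.

Measured so far in a functional assay on OVCAR-3 cells (Homo sapiens) for inhibition, read by sulforhodamine B assay, with a stated time of 48 h; a lower number here means a stronger inhibitor of growth, a higher number a weaker inhibitor of growth:
compound 1 `COc1ccc(/C=C/C2CC=CC(=O)O2)cc1` – 61.5 uM
compound 2 `COc1ccc(/C=C/C2CC=CC(=O)O2)c(OC)c1` – 5.6 uM
compound 3 `COc1cc(/C=C/C2CC=CC(=O)O2)cc(OC)c1` – 19.1 uM

Among these three, one single-point step is known: from compound 1 to compound 2 the change is methoxy in place of hydrogen on an aromatic carbon, and it brought an 11-fold lower number from compound 1 to compound 2 (1.04 log units; beyond the scatter). Compound 3 relates to compound 1 differently, and the difference between the two cores is not broken down here; what the values show is that compound 3 sits between the other two, with a lower number than compound 1 and a higher number than compound 2.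

Compound 4 `COc1cc(/C=C/C2CC=CC(=O)O2)cc(OC)c1OC` has not yet been measured in this assay. Relative to compound 3 it carries methoxy in place of hydrogen on an aromatic carbon. This is the same kind of change as that from compound 1 to compound 2, but the surroundings differ: in compound 2 the entering group sits ortho to a group of 9 heavy atoms and meta to a methoxy group, whereas in compound 4 it sits ortho to two methoxy groups and para to a group of 9 heavy atoms. A lowering is expected because an 11-fold lower number from compound 1 to compound 2 (1.04 log units; beyond the scatter) was large, though the altered surroundings argue for a more cautious size. Compound 4 is therefore expected to show a 3.2-fold lower number from compound 3 to compound 4 (0.50 log units; beyond the scatter). The estimated value of compound 4 in this assay is 6 uM, with a range from 2 uM to 20 uM.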

Compound 4, concentration for growth inhibition (reported as GI): 44.9 uM
For compound 4 the middle estimate is 7.5-fold (0.87 log units) below the measured one; measured number outside the range, above it.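

In this assay the entering methoxy gave a 2.4-fold higher number from compound 3 to compound 4 (0.37 log units; beyond the scatter), so the change that lowered the number on the core of compound 1 raised it on the core of compound 3. Set side by side, the two steps differ in direction as well as in size: the same change on two cores in this assay, an 11-fold lower number (1.04 log units; beyond the scatter) from compound 1 to compound 2 and a 2.4-fold higher number (0.37 log units; beyond the scatter) from compound 3 to compound 4, 26-fold (1.41 log units) apart, beyond the scatter of two such steps This shows that, in this series, the change cannot be carried from one core to another as a fixed increment, nor can its direction be assumed, but it does not show why the outcomes differ, and two steps, with the methoxy entering in different surroundings, support no general rule.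

The compounds shown leave open whether the higher number of compound 4 belongs to methoxy itself or would follow any group entering at that place, ortho to two methoxy groups and para to a group of 9 heavy atoms. A hydroxy group or an amine there, or a longer chain such as ethoxy, would help to separate these readings.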